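The source may hold more compounds than are shown below. What is called first, only, known or untested is meant among the compounds shown, and "the series" means these compounds.

In a functional assay on K562 cells (Homo sapiens) for cytotoxicity, read by MTT assay, with a stated time of 72 h (on this read-out higher numbers stand for lower toxicity in this test and lower numbers for higher toxicity in this test), compound 1 `C[Se]/C(=N\C(=O)c1cccs1)NC(=O)c1cccs1` reaches only the assay limit of > 100000 nM. Compound 2 `C[Se]/C(=N\C(=O)c1ccco1)NC(=O)c1ccco1` likewise gives only the limit > 100000 nM. Compound 3 `C[Se]/C(=N\C(=O)c1cnc2ccccc2c1)NC(=O)c1cnc2ccccc2c1` returns a number in this assay, 74800 nM. Compound 2 therefore stands at the limit of > 100000 nM in this assay, at which 2 of the 3 values shown sit, with nothing on this read-out to separate it from compound 1. Compound 4 `O=C(/N=C(/NC(=O)c1ccco1)[Se]Cc1ccccc1)c1ccco1` differs from compound 2 by phenyl in place of hydrogen on a saturated chain carbon bound to a selenium atom. For the measured compounds named here, no step between measured compounds speaks to this change, so the expected step of an at least 1.4-fold lower number from compound 2 to compound 4 (0.15 log units; that floor lies within the scatter) is modest, leaning toward higher toxicity, and a fair chance remains that only a limit is reported again. Compound 4 is estimated at 70000 nM in this assay, within 25000 nM to 150000 nM.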

Compound 4, concentration lethal to 50% of the cells: 80600 nM
For compound 4 the middle estimate is 1.2-fold (0.06 log units) below the measured one; the measured number falls inside the stated range.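

In this assay the change from methyl to benzyl gives the first step read at this position (an at least 1.2-fold lower number from compound 2 to compound 4 (0.09 log units; that floor lies within the scatter)). That step is only a floor, and it lies within the scatter, so compound 4 shows that this change yields a measured number but does not fix the size of any shift. Compound 2 offers only a limit to set against it: the limit of > 100000 nM in this assay, at which 2 of the 4 values shown sit.

From the compounds shown here alone, the true size of the step stays open. So does how a longer chain or an amine on the saturated chain carbon bound to a selenium atom would read.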